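The source may report more compounds than this note shows. Statements on the series, on what has been measured and on what is new or still open speak of the compounds shown alone.

In a functional assay (muscle tissue) with Cavia porcellus as the target (on this read-out lower numbers stand for an effect already at smaller amounts and higher numbers for an effect only at larger amounts of compound), compound 1 `COC(=O)C1=C(C)N=C(C)/C(=C(\O)OC)C1c1ccccc1F` gives 42.7 nM, compound 2 `COC(=O)C1=C(C)N=C(C)/C(=C(\O)OC)C1c1cccc(C#N)c1` gives 34.7 nM and compound 3 `COC(=O)C1=C(C)N=C(C)/C(=C(\O)OC)C1c1cc(C)ccc1C` gives 100 nM, the highest of the three numbers. Next comes compound 4 `COC(=O)C1=C(C)N=C(C)/C(=C(\O)OC)C1c1c(Cl)cccc1Cl`, with this change: 2,6-dichlorophenyl in place of 2,5-dimethylphenyl on a saturated ring carbon. Going by the values given here, the only guides are the swaps of the substituted phenyl group on the same saturated ring carbon. These are a 2.3-fold higher number from compound 1 to compound 3 (0.37 log units; beyond the scatter) and a 2.9-fold higher number from compound 2 to compound 3 (0.46 log units; beyond the scatter), both modest, while a 1.2-fold lower number from compound 1 to compound 2 (0.09 log units; within the scatter) stays within the scatter. Among the compounds with values here, no measured compound carries chlorine, so these steps indicate a size for such swaps but no firm direction for this one. The expected step is a 1.7-fold lower number from compound 3 to compound 4 (0.22 log units; within the scatter), so nothing beyond the scatter is expected. The estimate for compound 4 is 60 nM, with an expected range from 15 nM to 240 nM.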

Compound 4, half-maximal effective concentration: 1.91 nM
For compound 4 the middle estimate is 31-fold (1.50 log units) above the measured one; the whole stated range lies above it.
By their numbers in this assay, from the lowest: compound 4; then compounds 2 and 1 (each within the scatter of the next); then compound 3.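

In this assay this position proves far more sensitive than the earlier swaps suggested, with 2,6-dichlorophenyl giving three large steps (a 52-fold lower number from compound 3 to compound 4 (1.72 log units; beyond the scatter)) (an 18-fold lower number from compound 2 to compound 4 (1.26 log units; beyond the scatter)) (a 22-fold lower number from compound 1 to compound 4 (1.35 log units; beyond the scatter)). Among the compounds shown, the earlier swaps stayed modest or within the scatter, so the aryl group on the saturated ring carbon can move this read-out much further than they indicated.

From the compounds shown here alone, whether the gain follows the chlorine atoms or their arrangement in 2,6-dichlorophenyl stays open, and a dimethylphenyl group with its methyl groups arranged in the same way would separate the two. No measurement at hand explains the size of the gain.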